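Replacing a fluorinated side chain with a phenylsulfamoyl group

The source may hold more compounds than are shown below. What is called first, only, known or untested is meant among the compounds shown, and "the series" means these compounds.

Compound 1 `CC#C[C@H]1CN(S(=O)(=O)c2ccc(N)nc2)CCN1c1ccc(C(O)(CC#N)C(F)(F)F)cc1` gives 57 mL.min-1.g-1 in an ADME assay (liver) for metabolic stability, with Liver microsome (Rattus norvegicus) as the target, using microsomes and NADPH, with a stated time of 30 min (a lower number here means slower removal, a higher number faster removal of the compound), the highest of the three numbers. Compound 2 `CC#C[C@H]1CN(S(=O)(=O)c2ccc(N)nc2)CCN1c1ccc(S(=O)(=O)NC)cn1` gives 42 mL.min-1.g-1 in this assay, within the scatter of compound 1. Compound 3 `CC#C[C@H]1CN(S(=O)(=O)c2ccc(N)nc2)CCN1c1ccc(S(=N)(=O)C2CC2)cc1` gives 23 mL.min-1.g-1, and the step of a 2.5-fold lower number from compound 1 to compound 3 (0.39 log units; beyond the scatter) is the only one beyond the scatter. Compound 4 `CC#C[C@H]1CN(S(=O)(=O)c2ccc(N)nc2)CCN1c1ccc(S(=O)(=O)Nc2ccccc2)cc1` carries a group of 10 heavy atoms (6 carbon, 1 nitrogen, 2 oxygen, 1 sulfur; one six-membered aromatic ring of carbon only) in place of a group of 9 heavy atoms (4 carbon, 1 nitrogen, 1 oxygen, 3 fluorine; no ring), on an aromatic carbon. Among the compounds with values here, the change resembles the one to compound 3 only in that the same fluorinated group leaves; what enters differs, so the step to compound 3 is a loose guide, and a change of about the same size or none beyond the scatter is expected. Compound 4 is estimated at 45 mL.min-1.g-1 in this assay, between 20 mL.min-1.g-1 and 100 mL.min-1.g-1, an expected step of a 1.3-fold lower number from compound 1 to compound 4 (0.10 log units; within the scatter).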

Compound 4, intrinsic clearance in microsomes: > 399 mL.min-1.g-1
Compound 4: a limit, no number; the forecaster's own chance of this, stated with the estimate: 5%; middle value at least 8.8-fold (0.94 log units) from the limit.
By their numbers in this assay, from the lowest: compounds 3, 2 and 1 (each within the scatter of the next, the first and the last beyond it). At a limit, above all of these: compound 4.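

The fluorinated side chain and the sulfoximine-bearing compound 3 stayed within a modest range, but with phenylsulfamoyl on this aromatic carbon, this assay shows an at least 7.0-fold higher number from compound 1 to compound 4 (0.84 log units; beyond the scatter) and an at least 17-fold higher number from compound 3 to compound 4 (1.23 log units; beyond the scatter). This position can therefore change the read-out strongly, and two groups of similar size, the one that leaves and phenylsulfamoyl, need not behave alike. For compound 4 the result is a limit and not a number: the limit of > 399 mL.min-1.g-1 in this assay, at which 1 of the 4 values shown sits.

The compounds shown leave open whether the phenyl ring or the sulfonyl-nitrogen link matters more. A plain sulfamoyl group or a cyclohexylsulfamoyl group at this position would help separate the two.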